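The compounds below may be only part of what the source reports. "The series", "measured", "known", "first", "only" and "open" are said of these compounds alone.

Compound 1 `N#Cc1cc(-c2nc(C(c3ccc(F)cc3)c3ccc(F)cc3)sc2CC(=O)O)ccc1F` is the reference point of this account. Among the compounds with values here, in an in vitro assay on HEK385-7 cells for displacement of a labelled ligand from prostaglandin D2 receptor 2 (Homo sapiens) (on this read-out higher numbers stand for weaker inhibition and lower numbers for stronger inhibition), compound 1 gives 57 nM, the second highest of the three numbers measured so far. Its nearest neighbour is compound 3 `COc1cc(-c2nc(C(c3ccc(F)cc3)c3ccc(F)cc3)sc2CC(=O)O)ccn1`, which in this assay gives 29 nM; the step of a 2.0-fold lower number from compound 1 to compound 3 (0.29 log units; within the scatter). The furthest is compound 2 `CCC(c1ccccc1)c1nc(-c2ccc(Cl)cc2)c(CC(=O)O)s1`, which in this assay gives 190 nM, a higher number than compound 1 by a margin beyond the scatter.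

Compound 4 `NS(=O)(=O)c1ccc(-c2nc(C(c3ccc(F)cc3)c3ccc(F)cc3)sc2CC(=O)O)cc1` has not yet been measured. It differs from compound 1 by 4-sulfamoylphenyl in place of 3-cyano-4-fluorophenyl on an aromatic carbon. Within the data shown here, only one measured step bears on this change: the replacement of the same group on the same position of the shared core, a 2.0-fold lower number from compound 1 to compound 3 (0.29 log units; within the scatter), which stayed within the scatter. With a single comparable step of that size, no movement beyond the scatter is expected in this assay, so the step of a 1.0-fold lower number from compound 1 to compound 4 (0.02 log units; within the scatter) is estimated to be small. Compound 4 is therefore expected to give about 55 nM, with a range from 18 nM to 170 nM.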

Compound 4, half-maximal inhibitory concentration: 1500 nM
Compound 4: the middle estimate sits 27-fold (1.44 log units) below what was measured; the measured number lies above the stated range.
By their numbers in this assay, from the lowest: compounds 3 and 1 (each within the scatter of the next); then compound 2; then compound 4.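

In this assay, the position on the aromatic carbon next to the ring nitrogen proves sensitive to what it carries: 4-sulfamoylphenyl gives a 26-fold higher number from compound 1 to compound 4 (1.42 log units; beyond the scatter), and measured against the 2-methoxypyridin-4-yl group it gives a 52-fold higher number from compound 3 to compound 4 (1.71 log units; beyond the scatter). The only earlier replacement at this place, a 2.0-fold lower number from compound 1 to compound 3 (0.29 log units; within the scatter), stayed within the scatter, so that step did not show how far the number could move. Nothing available here accounts for the large rise.

The change removes the nitrile and the fluorine and brings in the sulfamoyl group in a single step, so the compounds shown cannot assign the rise to either side of it. An unsubstituted phenyl or a 4-methylsulfonylphenyl group on the same carbon would help to separate these possibilities.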